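The source may hold more compounds than are shown below. What is called first, only, known or untested is meant among the compounds shown, and "the series" means these compounds.

Of the compounds shown here, two built on one shared core have so far been tested in a functional assay on SR cells (Homo sapiens) for inhibition, read by sulforhodamine B assay, with a stated time of 48 h; on this read-out higher numbers stand for weaker inhibition of growth and lower numbers for stronger inhibition of growth. Compound 1 `COc1cc(-c2nn(-c3cccc(NC(=O)Nc4cc(C(F)(F)F)cc(C(F)(F)F)c4)c3)cc2-c2ccncc2)ccc1Cl` gives 1080 nM. Compound 2 `COc1cc(-c2nn(-c3cccc(NC(=O)c4cccc(C(F)(F)F)c4)c3)cc2-c2ccncc2)ccc1Cl` gives 838 nM, and these two numbers lie within the usual scatter of each other, so neither stands apart. Compound 3 `COc1cc(-c2nn(-c3cccc(NC(=O)Nc4cccc(C(F)(F)F)c4)c3)cc2-c2ccncc2)ccc1Cl` has not yet been measured. It differs from compound 2 in a single place: (3-(trifluoromethyl)phenyl)amino in place of 3-(trifluoromethyl)phenyl on a carbonyl carbon. Among the compounds with values here, the added nitrogen links the carbonyl carbon to the aromatic ring in the same way as in compound 1, while the single trifluoromethyl of compound 2 is kept. Because compound 1 gives 1080 nM and compound 2 gives 838 nM, the expected step of a 1.1-fold higher number from compound 2 to compound 3 (0.05 log units; within the scatter) is small and not beyond the scatter in either direction. The estimate for compound 3 in this assay is 950 nM, with a range from 450 nM to 2000 nM.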

Compound 3, concentration for 50% growth inhibition: 886 nM
Compound 3: middle estimate off by 1.1-fold (0.03 log units), on the high side, within the range that was stated.
By their numbers in this assay, from the lowest: compounds 2, 3 and 1 (each within the scatter of the next).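

In this assay, the swap of 3-(trifluoromethyl)phenyl for (3-(trifluoromethyl)phenyl)amino on the carbonyl carbon, which adds a nitrogen and a hydrogen-bond donor, gives a 1.1-fold higher number from compound 2 to compound 3 (0.02 log units; within the scatter) and so leaves the read-out unchanged within the scatter. Compound 1 and compound 2 differed in two places at once, and now the second place can be read alone: hydrogen in place of trifluoromethyl on an aromatic carbon gives a 1.2-fold lower number from compound 1 to compound 3 (0.09 log units; within the scatter) and is likewise no change beyond the scatter. Nothing available here explains why neither change registers.

All three compounds keep an aromatic ring on this carbonyl carbon and at least one trifluoromethyl on that ring. Going by these compounds, whether a carboxylic acid or an amine on that ring, or a longer alkyl chain in place of the ring, would shift the number beyond the scatter remains open.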